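Swapping a ring group on an amide nitrogen

The source may report more compounds than this note shows. Statements on the series, on what has been measured and on what is new or still open speak of the compounds shown alone.

Measured in a physicochemical assay for solubility (on this read-out lower numbers stand for lower solubility and higher numbers for higher solubility), so far, each value being a limit of the assay and not a number:
- compound 1 `CNC(=O)c1cc(C(=O)N[C@H]2CC[C@H](O)CC2)n([C@@H](C)c2ccccc2)n1` gives >= 180 ug/mL as a limit
- compound 2 `CNC(=O)c1cc(C(=O)N[C@H]2[C@@H]3COC[C@@H]32)c([C@@H](C)c2ccccc2)o1` gives >= 131 ug/mL as a limit
- compound 3 `CNC(=O)c1cc(C(=O)N[C@H]2[C@@H]3C[C@@H](O)C[C@@H]32)c([C@@H](C)c2ccccc2)o1` gives >= 172 ug/mL as a limit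

Compound 1 stands at a limit, >= 180 ug/mL, and no exact number is known for it. The other two values are limits as well.

Compound 4 `CNC(=O)c1cc(C(=O)N[C@H]2[C@@H]3C[C@@H](O)C[C@@H]32)n([C@@H](C)c2ccccc2)n1` keeps the core of compound 1 and alters one group, on an amide-type nitrogen whose other neighbours are: carbonyl carbon. The change is a group of 7 heavy atoms (6 carbon, 1 oxygen; one three-membered non-aromatic ring of carbon only, one five-membered non-aromatic ring of carbon only) in place of a group of 7 heavy atoms (6 carbon, 1 oxygen; one six-membered non-aromatic ring of carbon only), on an amide-type nitrogen and the 4-hydroxycyclohexyl is the group that leaves.

Among the compounds with values here, only one measured step brings in the entering group, a step that the two limits leave unreadable from compound 2 to compound 3 and it does so on the core of compound 2. That step offers no size to carry over, so nothing measured points up or down. Compound 3, which carries the entering group, stands at a limit, >= 172 ug/mL, and compound 4 is expected to end at a limit too.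

The expected change is an at least 1.0-fold lower number from compound 1 to compound 4 (0.03 log units; that floor lies within the scatter) with no shift beyond the scatter anticipated in this assay for this swap. For compound 4 the estimated value is 165 ug/mL with an expected range from 100 ug/mL to 200 ug/mL in a single measurement.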

Compound 4, solubility: >= 291 ug/mL
Compound 4 gave a limit, no number; the forecaster's own chance of this, stated with the estimate: 75%; at least 1.7-fold (0.24 log units) between middle value and limit.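

In this assay compound 4 gives >= 291 ug/mL, which is a limit and not a number. Compound 1 gives >= 180 ug/mL, also a limit. With a limit on both sides, the step from compound 1 to compound 4 cannot be read. The compounds shown leave open what exact value any of them has, and so whether replacing the 4-hydroxycyclohexyl group moves this read-out at all.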